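Amino for Nitro on Two Sulfonamide Cores

A few compounds are considered here, and "the series" means these few. Any claim that something is new, unique, unknown or untested is made for them only; others in the source may bear on it.

Compound 1, `COc1ccc(NS(=O)(=O)/C=C/c2c(F)c(F)c(F)c(F)c2F)cc1[N+](=O)[O-]`: 100000 nM
Compound 2, `COc1ccc(NS(=O)(=O)/C=C/c2c(F)c(F)c(F)c(F)c2F)cc1N`: 75000 nM
Compound 3, `COc1ccc(NS(=O)(=O)/C=C/c2cc(OC)c(OC)c(OC)c2)cc1[N+](=O)[O-]`: 75000 nM

Of the compounds shown here, three have been tested in a functional assay on K562 cells (Homo sapiens) for cytotoxicity, read by trypan blue exclusion, with a stated time of 96 h; a higher number here means a weaker inhibitor, a lower number a stronger inhibitor. Compound 1 and compound 2 share one core and differ in a single place: amino in place of nitro on an aromatic carbon. The step of a 1.3-fold lower number from compound 1 to compound 2 (0.12 log units; within the scatter) lies within the scatter, so the two values cannot be told apart. Compound 3 is built on a different core; the difference between the two cores is not broken down here. In this assay compound 3 gives a value level with compound 2 at the digits shown, and it also lies within the scatter of compound 1.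

Compound 4, `COc1ccc(NS(=O)(=O)/C=C/c2cc(OC)c(OC)c(OC)c2)cc1N`, has not yet been measured. It relates to compound 3 by the same change, at the same place: amino in place of nitro on an aromatic carbon. Because the step of a 1.3-fold lower number from compound 1 to compound 2 (0.12 log units; within the scatter) stayed within the scatter on the first core, a step of similar small size is expected on the second core. The step that this expectation means is a 1.1-fold lower number from compound 3 to compound 4 (0.03 log units; within the scatter). Compound 4 is expected to give about 70000 nM, most likely between 35000 nM and 150000 nM.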

Compound 4, half-maximal inhibitory concentration: 15000 nM
Estimate against measurement, compound 4: 4.7-fold (0.67 log units) above, outside the stated range (below it).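

In this assay, putting amino in place of nitro on the core of compound 3 gives a 5.0-fold lower number from compound 3 to compound 4 (0.70 log units; beyond the scatter). The same change therefore does not carry over at the same size from one core to the other, and its size on the core of compound 1 was no reliable guide to its size here: the same change on two cores in this assay, a 1.3-fold lower number (0.12 log units; within the scatter) from compound 1 to compound 2 and a 5.0-fold lower number (0.70 log units; beyond the scatter) from compound 3 to compound 4, 3.8-fold (0.57 log units) apart, beyond the scatter of two such steps. Going by these compounds alone, with only one pair on each core, this shows that the effect of the change depended on the core in these four compounds, but it does not show which part of the core is responsible, why the steps differ, or what would happen on any other core.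

The compounds shown leave open which features of the two cores separate the steps, for instance whether a core carrying a single fluorine atom or a single methoxy group on the far ring would behave like either core here. They also leave open how a hydroxyl group or an acetylamino group would compare with amino and nitro at the same place.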